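The source may report more compounds than this note shows. Statements on the series, on what has been measured and on what is new or still open speak of the compounds shown alone.

Measured compounds in an ADME assay on Vero cells (Chlorocebus sabaeus) for cytotoxicity; on this read-out higher numbers stand for an effect only at larger amounts of compound and lower numbers for an effect already at smaller amounts:
Compound 1 `COc1ccc(Nc2ncnc3c(=N)n(NC(=O)c4ccncc4)cnc23)cc1`: 1.15 ug/mL
Compound 2 `COc1ccc(Nc2ncnc3c(=N)n(NC(=O)c4ccccc4)cnc23)cc1`: 2.12 ug/mL
Compound 3 `COc1ccc(Nc2ncnc3c(=N)n(NC(=O)c4ccco4)cnc23)cc1`: "not determined" (no result reported)

Compound 2 and compound 1 give numbers that lie within the scatter of each other: the step of a 1.8-fold higher number from compound 1 to compound 2 (0.27 log units; within the scatter) is within the scatter, so the two cannot be told apart, and compound 3 contributes no number. Compound 4 `N=c1c2ncnc(Nc3ccc(F)cc3)c2ncn1NC(=O)c1ccccc1` differs from compound 2 by fluoro in place of methoxy on an aromatic carbon, a change in the (4-methoxyphenyl)amino part. Among the compounds with values here, no measured step bears on this change: the only step in hand concerned the group on the carbonyl carbon and stayed within the scatter. With nothing pointing in either direction, compound 4 is expected to show a step of a 1.0-fold lower number from compound 2 to compound 4 (0.00 log units; within the scatter), staying within the scatter, with an estimated 2.1 ug/mL and a range from 0.8 ug/mL to 5.5 ug/mL.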

Compound 4, half-maximal effective concentration: 3.05 ug/mL
Estimate against measurement, compound 4: 1.5-fold (0.16 log units) below; measured number inside the range.
By their numbers in this assay, from the lowest: compounds 1, 2 and 4 (each within the scatter of the next, the first and the last beyond it).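

This is the first change in the (4-methoxyphenyl)amino part of these compounds. In this assay, fluoro in place of methoxy gives a 1.4-fold higher number from compound 2 to compound 4 (0.16 log units; within the scatter), so this swap cannot be told apart from no change at all. Nothing available explains why these two groups read alike.

As far as these compounds go, whether an amine, a carboxylic acid or a longer chain at this same aromatic carbon would give a step beyond the scatter remains open. Also open, from the compounds shown here alone, is whether fluoro in place of methoxy would read the same with pyridin-4-yl on the carbonyl carbon.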